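This account rests on a few compounds, and the source may have more. Where it says the series, first, only, none or still open, it means among the compounds named here.

Compound 1 `Oc1cccc(-c2cc(-c3ccc(F)cc3)cc(-c3cccc(O)c3)n2)c1` gives 6870 nM in a functional assay on T47D cells (Homo sapiens) for inhibition; on this read-out higher numbers stand for weaker inhibition and lower numbers for stronger inhibition. Compound 2 `Oc1cccc(-c2cc(-c3cccc(C(F)(F)F)c3)cc(-c3ccccc3O)n2)c1` gives 6340 nM. Compound 3 `Oc1cccc(-c2cc(-c3ccccc3C(F)(F)F)cc(-c3cccc(O)c3)n2)c1` gives 4350 nM.

Compound 3 carries the lowest of the three numbers, yet its gap to compound 2 and its gap to compound 1 both lie within the scatter, so the three stand level. Among the compounds with values here, the one measured step on the shared core, a 1.6-fold lower number from compound 1 to compound 3 (0.20 log units; within the scatter), likewise stayed within the scatter. Compound 4 `Oc1cccc(-c2cc(-c3cccc(C(F)(F)F)c3)cc(-c3cccc(O)c3)n2)c1` differs from compound 3 only in this: 3-(trifluoromethyl)phenyl in place of 2-(trifluoromethyl)phenyl on an aromatic carbon. Compound 2 already holds a 3-(trifluoromethyl)phenyl and sits near compound 3, which suggests no step beyond the scatter. The expected step is a 1.1-fold higher number from compound 3 to compound 4 (0.06 log units; within the scatter), and compound 4 is expected at 5000 nM, between 2500 nM and 10000 nM.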

Compound 4, half-maximal inhibitory concentration: 4970 nM
For compound 4 the middle estimate is 1.0-fold (0.00 log units) above the measured one, and the stated range covers the measured number.
By their numbers in this assay, from the lowest: compounds 3, 4, 2 and 1 (each within the scatter of the next).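

In this assay, 3-(trifluoromethyl)phenyl in place of 2-(trifluoromethyl)phenyl gives a 1.1-fold higher number from compound 3 to compound 4 (0.06 log units; within the scatter) and shows that, at this position opposite the ring nitrogen, the two placements of the trifluoromethyl group cannot be told apart. The swap of 3-hydroxyphenyl for 2-hydroxyphenyl gives a 1.3-fold lower number from compound 2 to compound 4 (0.11 log units; within the scatter) and also stays within the scatter. So does 3-(trifluoromethyl)phenyl in place of 4-fluorophenyl, with a 1.4-fold lower number from compound 1 to compound 4 (0.14 log units; within the scatter) as its step. Still open, going by these compounds, is whether an amine or a carboxylic acid on this phenyl would carry the number beyond the scatter. Nothing available accounts for these level results.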